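Urea chain variation in aryl sulfonate antiproliferatives

A few compounds are considered here, and "the series" means these few. Any claim that something is new, unique, unknown or untested is made for them only; others in the source may bear on it.

Measured so far:
- compound 1 `CC(C)c1ccccc1OS(=O)(=O)c1ccc(NC(=O)CCCl)cc1`: in a functional assay on M21 cells (Homo sapiens) for antiproliferative activity, read by sulforhodamine B assay, with a stated time of 48 h (a lower number here means a stronger inhibitor, a higher number a weaker inhibitor), compound 1 gives 14000 nM
- compound 2 `CCCNC(=O)Nc1ccc(S(=O)(=O)Oc2ccccc2C(C)C)cc1`: in this assay compound 2 gives 5100 nM

Compound 2 has the lowest of the two numbers; its nearest neighbour is compound 1, with a 2.7-fold lower number from compound 1 to compound 2 (0.44 log units; beyond the scatter) between them. Compound 3 `CC(C)c1ccccc1OS(=O)(=O)c1ccc(NC(=O)NC2CCCC2)cc1` carries cyclopentyl in place of propyl on an amide-type nitrogen. For the measured compounds named here, that measured step alters the carbonyl substituent, not the amide nitrogen, so no measured step bears directly on this change. Without precedent in the series, a change within scatter is expected, a 1.1-fold lower number from compound 2 to compound 3 (0.05 log units; within the scatter). Compound 3 is therefore estimated at 4500 nM, between 1500 nM and 13000 nM.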

Compound 3, half-maximal inhibitory concentration: 6100 nM
Compound 3: middle estimate off by 1.4-fold (0.13 log units), on the low side; the measured number falls inside the stated range.
By their numbers in this assay, from the lowest: compounds 2 and 3 (each within the scatter of the next); then compound 1.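

In this assay, cyclopentyl on the amide-type nitrogen gives a 1.2-fold higher number from compound 2 to compound 3 (0.08 log units; within the scatter), so this position accepts a five-membered carbon ring without separating compound 3 from the propyl compound 2. The cyclopentylamino group also keeps the advantage over the 2-chloroethyl group, with a 2.3-fold lower number from compound 1 to compound 3 (0.36 log units; beyond the scatter) and a size close to the earlier propylamino step. Nothing on hand explains either step.

Open, as far as these compounds go, is whether a cyclohexyl or phenyl group, or a longer chain ending in an amine or a carboxylic acid, would move the number beyond the scatter from compound 2.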